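2H-tetrazol-5-yl in Place of Chloro on Compound 2

A few compounds are considered here, and "the series" means these few. Any claim that something is new, unique, unknown or untested is made for them only; others in the source may bear on it.

In a functional assay on the whole organism (stomach) with Rattus norvegicus as the target (on this read-out lower numbers stand for an effect already at smaller amounts and higher numbers for an effect only at larger amounts of compound), compound 1 (`N#Cc1ccc(C(=O)Nc2ccc(-c3nn[nH]n3)cc2)cc1`) gives 54.4 mg/kg and compound 2 (`O=C(O)c1cc(NC(=O)c2ccc(Cl)cc2)cc(C(=O)O)c1`) gives 97.3 mg/kg and these two values lie within the scatter of each other. Compound 3 (`O=C(O)c1cc(NC(=O)c2ccc(-c3nn[nH]n3)cc2)cc(C(=O)O)c1`) has 2H-tetrazol-5-yl in place of chloro on an aromatic carbon. For the measured compounds named here, no measured step shows this change directly. Compound 1, which also bears 2H-tetrazol-5-yl, gives 54.4 mg/kg and stays within the scatter of compound 2, so only a modest move toward lower numbers is expected in this assay and it may not clear the scatter. The expected step is a 1.8-fold lower number from compound 2 to compound 3 (0.25 log units; within the scatter) in this estimate. Compound 3 is estimated at 55 mg/kg with a range from 18 mg/kg to 150 mg/kg expected.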

Compound 3, dose for 50% inhibition: 8.2 mg/kg
The estimate for compound 3 lay 6.7-fold (0.83 log units) above the measured number; measured number outside the range, below it.
By their numbers in this assay, from the lowest: compound 3; then compounds 1 and 2 (each within the scatter of the next).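

For the compounds shown here, putting 2H-tetrazol-5-yl in place of chloro on this aromatic carbon, para to a large group, gives a 12-fold lower number from compound 2 to compound 3 (1.07 log units; beyond the scatter) in this assay and is the first direct reading of this change. Compound 1 carries the same group but differs from compound 2 in more than one place, so it could not show how strongly this position responds. Nothing at hand accounts for the size of the step. On these data alone, whether an amine or a longer chain at this place would give a step of similar size remains open, as does whether the same change would act alike on the core of compound 1.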